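The source may report more compounds than this note shows. Statements on the series, on what has been measured and on what is new or still open speak of the compounds shown alone.

In a physicochemical assay for solubility, measured as kinetic solubility, at pH 2 (on this read-out higher numbers stand for higher solubility and lower numbers for lower solubility), compound 1 `CC(C)C(c1ccc(-c2ccc3cccc(F)c3c2)[nH]c1=O)C1SC(=O)NC1=O` gives 11300 nM. Compound 3 `CC(C)/C(=C1/SC(=O)NC1=O)c1ccc(-c2ccc3cccc(F)c3c2)[nH]c1=O` gives 9200 nM, within the usual scatter of the number for compound 1. Compound 2 `CC(C)C(/C=C1\OC(=O)NC1=O)c1cc(Cl)c(-c2ccc3cccc(F)c3c2)[nH]c1=O` gives 3200 nM, a lower number than compound 1, and this gap lies beyond the scatter. Compound 4 `CC(C)C(c1ccc(-c2ccc3cccc(F)c3c2)[nH]c1=O)C1C(=O)NC(=O)N1C` is still unmeasured. It keeps the core of compound 1 but carries 3-methyl-2,5-dioxoimidazolidin-4-yl in place of 2,4-dioxo-1,3-thiazolidin-5-yl on a saturated chain carbon bound to an aromatic carbon and a saturated chain carbon. For the measured compounds named here, no measured compound carries the new group, and no measured pair shows a single change, so the data offer no direct guide. The expected step, a 1.1-fold higher number from compound 1 to compound 4 (0.03 log units; within the scatter), is none beyond the scatter. Compound 4 is expected at 12000 nM, with an estimated range of 4500 nM to 32000 nM.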

Compound 4, solubility: 13600 nM
Compound 4: middle estimate off by 1.1-fold (0.05 log units), on the low side, within the range that was stated.
By their numbers in this assay, from the lowest: compound 2; then compounds 3, 1 and 4 (each within the scatter of the next).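

For the compounds shown here, at this saturated chain carbon, the step from 2,4-dioxo-1,3-thiazolidin-5-yl to 3-methyl-2,5-dioxoimidazolidin-4-yl in this assay is a 1.2-fold higher number from compound 1 to compound 4 (0.08 log units; within the scatter) and so gives the first comparison here of compounds differing in one place. On this read-out the two groups cannot be told apart, although they differ in ring atoms and size. Nothing on hand accounts for this result.
Going by these compounds, how far this holds for other groups stays open. The compounds shown do not reveal what an amine or a carboxylic acid on this same carbon would give.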